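The source may report more compounds than this note shows. Statements on the series, on what has been measured and on what is new or still open speak of the compounds shown alone.

Measured in a functional assay on HepG2 cells (Homo sapiens) for inhibition, read by MTT assay, with a stated time of 72 h; on this read-out lower numbers stand for stronger inhibition and higher numbers for weaker inhibition:
compound 1 `O=C1/C(=C\c2ccccc2)c2c(ncn2COCc2ccccc2)CCN1Cc1ccccc1`: 13900 nM
compound 2 `COc1cc(/C=C2\C(=O)N(Cc3ccccc3)CCc3ncn(COCc4ccccc4)c32)cc(OC)c1OC`: 10000 nM

Among the measured compounds shown here, compound 2 gives 10000 nM and, on the two numbers so far, stands level with compound 1 within the scatter. The next step leads to compound 3 `O=C1/C(=C\c2ccncc2)c2c(ncn2COCc2ccccc2)CCN1Cc1ccccc1`, not yet measured. The change is pyridin-4-yl in place of 3,4,5-trimethoxyphenyl on a double-bonded chain carbon bound to a double-bonded ring carbon.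

For the measured compounds named here, one measured step bears on this change, at the same place: a 1.4-fold lower number from compound 1 to compound 2 (0.14 log units; within the scatter). That step stays within the scatter, so no step beyond the scatter is expected in this assay here either, and no direction can be drawn from it. Going by the values given here, the expectation rests on that single step, and no measured compound yet carries a ring with a hetero atom at this place. The expected step is a 1.2-fold higher number from compound 2 to compound 3 (0.08 log units; within the scatter), which stays within the scatter. For compound 3 the estimate is 12000 nM, with an expected range of 5000 nM to 30000 nM.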

Compound 3, half-maximal inhibitory concentration: > 100000 nM
Compound 3: only a limit was reported; the forecaster's own chance of this, stated with the estimate: 10%; middle value at least 8.3-fold (0.92 log units) from the limit.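

In this assay, the group on a double-bonded chain carbon bound to a double-bonded ring carbon had so far shown no step beyond the scatter, but pyridin-4-yl now gives an at least 10-fold higher number from compound 2 to compound 3 (1.00 log units; beyond the scatter), and measured against phenyl it gives an at least 7.1-fold higher number from compound 1 to compound 3 (0.85 log units; beyond the scatter). On these data alone, both steps lie beyond the scatter, and their true size is unknown, as the value of compound 3 is a limit of the assay and not a number: the limit of > 100000 nM in this assay, at which 1 of the 3 values shown sits. This place in the series therefore does respond to the aromatic ring it carries: the two carbon-only rings, phenyl and 3,4,5-trimethoxyphenyl, stand level within the scatter, while the one ring with a hetero atom gives a much higher number.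

With pyridin-4-yl as the only ring of this kind, the compounds shown cannot separate an effect of having a ring nitrogen at all from an effect of where it sits, a question that pyridin-3-yl or pyridin-2-yl would address. As far as these compounds go, it also remains open whether a five-membered ring such as thiophen-2-yl, or a phenyl carrying a dimethylamino group, would stay level with the carbon-only rings or follow compound 3.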